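A few compounds are considered here, and "the series" means these few. Any claim that something is new, unique, unknown or untested is made for them only; others in the source may bear on it.

Compound 1 `Cc1ccccc1-c1nn(-c2ccc(F)cc2F)cc1CNCCCCO`: in an ADME assay on Huh-7 cells (Homo sapiens) for cytotoxicity (on this read-out lower numbers stand for higher toxicity in this test and higher numbers for lower toxicity in this test), compound 1 gives a limit of the assay, > 20000 nM. Compound 2 `CN1CCN(CCNCc2cn(-c3ccc(F)cc3F)nc2-c2cccc(Cl)c2)CC1`: in this assay compound 2 gives 15000 nM. Compound 3 `Cc1ccccc1-c1nn(-c2ccc(F)cc2F)cc1CNCCCN1CCN(C)CC1`: in this assay compound 3 gives a limit of the assay, > 20000 nM.

Among the compounds with values here, compound 2 is thus the only compound of the three with a number; the other two values sit at the limit of > 20000 nM in this assay, at which 2 of the 3 values shown sit. Within the data shown here, the one step that connects two measured compounds, a step that the two limits leave unreadable from compound 1 to compound 3, changes the chain end rather than the aryl group, so no measured step bears on the change to compound 4 `CN1CCN(CCNCc2cn(-c3ccc(F)cc3F)nc2-c2ccc(S(=O)(=O)N(C)C)cc2)CC1`, in which (4-(dimethylsulfamoyl)phenyl in place of 3-chlorophenyl on an aromatic carbon). With nothing to read from, no step beyond the scatter is expected in this assay, and a 1.1-fold higher number from compound 2 to compound 4 (0.05 log units; within the scatter) is the expected step. Compound 4 is estimated at 17000 nM, between 7000 nM and 40000 nM.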

Compound 4, half-maximal cytotoxic concentration: > 20000 nM
Compound 4: a limit, no number; the forecaster's own chance of this, stated with the estimate: 45%; middle value at least 1.1-fold (0.07 log units) away from the limit.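

At this position, on an aromatic carbon of the five-membered ring, 4-(dimethylsulfamoyl)phenyl in place of 3-chlorophenyl gives in this assay an at least 1.3-fold higher number from compound 2 to compound 4 (0.12 log units; that floor lies within the scatter). Within the data shown here, this is the first measured change at this aryl group, and the larger group brings no lower number. Compound 4 gives a limit, not a number, so the step has only a floor: the limit of > 20000 nM in this assay, at which 3 of the 4 values shown sit.

Going by these compounds, how far beyond that limit compound 4 lies stays open. So does what a 4-carboxyphenyl or 4-aminophenyl group would give at this position.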